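The compounds below may be only part of what the source reports. "The series", "measured", "known", "first", "only" and "open" are said of these compounds alone.

Compound 2 `O=C(Nc1cccc(Cl)c1)O/N=C(\C1CCCCC1)C(Cc1cc[nH]c1)C1CCCCC1` stands lowest of the two numbers measured in an assay on isolated protein for displacement of a labelled ligand from metabotropic glutamate receptor 5 (Rattus norvegicus) (a higher number here means a weaker inhibitor, a lower number a stronger inhibitor), giving 16.1 nM; its nearest neighbour, compound 1 `O=C(Nc1cccc(Cl)c1)O/N=C(\C1CCCCC1)C(Cc1ccccn1)C1CCCCC1`, gives 40.4 nM. Compound 3 `O=C(Nc1cccc(Cl)c1)O/N=C(\C1CCCCC1)C(Cc1ccccc1)C1CCCCC1` differs from compound 2 by phenyl in place of 1H-pyrrol-3-yl on a saturated chain carbon, two bonds along the chain from a carbon with a double bond to nitrogen and a saturated ring carbon. Within the data shown here, the single measured step that bears on this position, a 2.5-fold lower number from compound 1 to compound 2 (0.40 log units; beyond the scatter), shows that swapping the aromatic group here moves the number only modestly. Nothing measured carries a phenyl at this place, so the step of a 1.7-fold higher number from compound 2 to compound 3 (0.24 log units; within the scatter) is expected to be small, most likely toward a somewhat higher number. Compound 3 is therefore estimated at 28 nM, within a range from 10 nM to 80 nM.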

Compound 3, inhibition constant: 16 nM
Beside the measured number, compound 3's estimate is 1.8-fold (0.24 log units) above it; measured number inside the range.
By their numbers in this assay, from the lowest: compounds 3 and 2 (each within the scatter of the next); then compound 1.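

In this assay, the step of a 1.0-fold lower number from compound 2 to compound 3 (0.00 log units; within the scatter) shows that at this place phenyl, with 0 hydrogen-bond donors, cannot be told apart from 1H-pyrrol-3-yl, with 1 hydrogen-bond donor. Among these compounds, the step of a 2.5-fold lower number from compound 1 to compound 3 (0.40 log units; beyond the scatter) leaves pyridin-2-yl as the one group of the three that stands apart, at a modest distance. Nothing measured here accounts for this pattern.

The compounds shown leave open whether a non-aromatic group, such as cyclohexyl or an amine, would be tolerated in place of the ring. They also leave open how a longer chain in place of benzyl, or a methoxy or fluoro group on the phenyl, would read.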